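Aroylthiourea to sulfonylthiourea on a shared aryloxyalkoxy core

The source may hold more compounds than are shown below. What is called first, only, known or untested is meant among the compounds shown, and "the series" means these compounds.

Compound 1 `O=C(NC(=S)N1CCc2c(OCCCCCOc3ccc(Cl)cc3)cccc21)c1cccc([N+](=O)[O-])c1`: 12100 nM
Compound 2 `O=C(NC(=S)N1CCc2c(OCCCCCOc3ccc(Cl)cc3)cccc21)c1ccc([N+](=O)[O-])cc1`: 13600 nM
Compound 3 `CCCC(=O)NC(=S)N1CCc2c(OCCCCCOc3ccc(Cl)cc3)cccc21`: > 50000 nM

In an ADME assay on Huh-7 cells (Homo sapiens) for cytotoxicity (a higher number here means that more compound is tolerated, a lower number that less compound is tolerated), compound 1 and compound 2 sit close together, and a 1.1-fold higher number from compound 1 to compound 2 (0.05 log units; within the scatter) is within the scatter. Compound 3 stands apart: in this assay compound 3 gives only a limit, > 50000 nM, so its true value is not known. From the two aromatic amides to compound 3, an at least 4.1-fold higher number from compound 1 to compound 3 (0.61 log units; beyond the scatter) and an at least 3.6-fold higher number from compound 2 to compound 3 (0.56 log units; beyond the scatter) are both at least modest rises. Compound 4 `O=S(=O)(NC(=S)N1CCc2c(OCCCCCOc3ccc(Cl)cc3)cccc21)c1ccccc1` has not been measured. Its change from compound 3 is phenylsulfonyl in place of propylcarbonyl on an amide-type nitrogen. The measured steps both reward losing an aromatic ring on the acyl carbon, and compound 4 brings an aromatic ring back, though through a sulfonyl rather than a carbonyl. A fall is therefore expected, of about an at least 1.6-fold lower number from compound 3 to compound 4 (0.22 log units; that floor lies within the scatter), giving compound 4 an estimated 30000 nM, between 10000 nM and 60000 nM.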

Compound 4, half-maximal cytotoxic concentration: > 50000 nM
Compound 4: no number, only a limit (the forecaster's own chance of this, stated with the estimate: 35%); middle value at least 1.6-fold (0.22 log units) away from the limit.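

An aromatic ring at this position does not by itself bring the lower numbers in this assay: with phenylsulfonyl on the amide-type nitrogen there is an at least 3.6-fold higher number from compound 2 to compound 4 (0.56 log units; beyond the scatter) and an at least 4.1-fold higher number from compound 1 to compound 4 (0.61 log units; beyond the scatter). The step from compound 3 to compound 4 cannot be read, because each compound gives only a limit: the limit of > 50000 nM in this assay, at which 2 of the 4 values shown sit.

Still open, going by these compounds, is whether the nitro group or the carbonyl link goes with the lower numbers, since the two change together in these steps. A plain benzoyl group or a nitrophenylsulfonyl group on that nitrogen would separate them.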